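The source may hold more compounds than are shown below. What is called first, only, known or untested is meant among the compounds shown, and "the series" means these compounds.

Measured so far:
- compound 1 `O=C(O)c1cc(=O)c2c(OCCCCCOc3ccccc3)cccc2o1`: 17.5 ug/mL
- compound 2 `O=C(O)c1cc(=O)c2cc(OCCCOc3ccccc3)ccc2o1`: 3.3 ug/mL

In a functional assay on ileum (Cavia porcellus) for antagonist activity, with a stated time of 30 s (a lower number here means a stronger inhibitor, a higher number a weaker inhibitor), compound 2 gives 3.3 ug/mL, the lower of the two numbers, which makes it the stronger inhibitor of the pair. Its gap to compound 1 lies beyond the usual scatter of repeated measurements.

The next compound, compound 3 `O=C(O)c1cc(=O)c2cc(OCCCCCOc3ccccc3)ccc2o1`, has not yet been measured. It differs from compound 2 in one place: 2-phenoxyethyl in place of phenoxy on a saturated chain carbon, three bonds along the chain from an oxygen on an aromatic ring. That is, 2-phenoxyethyl stands in place of phenoxy on a saturated chain carbon, three bonds along the chain from an oxygen on an aromatic ring. Going by the values given here, no measured pair shows this change, so any forecast is loose. Compound 1, at 17.5 ug/mL, shows that numbers here can run higher, so a small upward drift in this assay is expected, but nothing beyond the scatter.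

The expected change is a 1.4-fold higher number from compound 2 to compound 3 (0.13 log units; within the scatter).

Compound 3 is estimated at about 4.5 ug/mL, with a likely range of 1.3 ug/mL to 15 ug/mL.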

Compound 3, half-maximal inhibitory concentration: 3.3 ug/mL
Beside the measured number, compound 3's estimate is 1.4-fold (0.13 log units) above it, within the range that was stated.
By their numbers in this assay, from the lowest: compounds 2 and 3 (each within the scatter of the next); then compound 1.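

In this assay, swapping phenoxy for 2-phenoxyethyl gives no change at the digits printed from compound 2 to compound 3 (within the scatter), so at this place the larger group leaves the two compounds indistinguishable. Compound 1 carries the same chain as compound 3, joined at a different place on the shared core, and the printed values separate them: compound 1 gives 17.5 ug/mL, while compound 3 gives 3.3 ug/mL. Nothing available explains why the added chain length leaves the number as it is.

As far as these compounds go, whether a longer chain would also match compound 2 remains open. So does the outcome of replacing the end phenoxy with an amine or of adding a chlorine to its ring.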